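Notes on the change from compound 3 to compound 4

A few compounds are considered here, and "the series" means these few. Any claim that something is new, unique, unknown or untested is made for them only; others in the source may bear on it.

Compound 1 `Cc1ccc(-c2cn(-c3ccc(CN4CCCC4)cc3)nn2)cc1Nc1nccc(-c2cccnc2)n1` gives 3890 nM in a functional assay on K562 cells (Homo sapiens) for inhibition, read by MTT assay, with a stated time of 72 h; a higher number here means a weaker inhibitor, a lower number a stronger inhibitor. Compound 2 `Cc1ccc(-c2nnc(-c3ccc(CN4CCN(C)CC4)c(C(F)(F)F)c3)o2)cc1Nc1nccc(-c2cccnc2)n1` gives 510 nM in this assay. Compound 3 `Cc1ccc(-c2nnc(-c3ccc(C)c(C(F)(F)F)c3)o2)cc1Nc1nccc(-c2cccnc2)n1` stands apart, as its result is a limit of the assay and not a number: in this assay compound 3 gives > 30000 nM. Going by the values given here, the only measured step between neighbours, an at least 58-fold higher number from compound 2 to compound 3 (1.76 log units; beyond the scatter), follows removal of a basic group from the side chain and ends at the limit described in the limit of > 30000 nM in this assay, at which 1 of the 3 values shown sits.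

Compound 4 `Cc1ccc(-c2nnc(-c3cccnc3)o2)cc1Nc1nccc(-c2cccnc2)n1` differs from compound 3 by pyridin-3-yl in place of 4-methyl-3-(trifluoromethyl)phenyl on an aromatic carbon. Among the compounds with values here, no measured step covers this exchange, and the one measured step concerns a different position, so nothing here says in which direction it should move. Compound 3 sits at the limit, so any change can only be read as staying at or coming back from it. Compound 4, like compound 3, carries no basic side chain, and it is therefore expected to remain weak, with the step of an at least 1.2-fold lower number from compound 3 to compound 4 (0.07 log units; that floor lies within the scatter) expected as a rough guess only. The estimate for compound 4 in this assay is 25000 nM, in the range 6000 nM to 30000 nM.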

Compound 4, half-maximal inhibitory concentration: > 30000 nM
Compound 4 ended at the assay's limit; the forecaster's own chance of this, stated with the estimate: 55%; at least 1.2-fold (0.07 log units) between middle value and limit.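

Compound 3 and compound 4 both sit at a limit of the assay and not at a number, so no step can be read between them: the limit of > 30000 nM in this assay, at which 2 of the 4 values shown sit.

The compounds shown leave open whether exchanging 4-methyl-3-(trifluoromethyl)phenyl for pyridin-3-yl changes anything in this assay when the compound's value is not at that limit.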